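A Methyl on the Furan of Compound 3

The compounds below may be only part of what the source reports. "The series", "measured", "known", "first", "only" and "open" are said of these compounds alone.

In a functional assay on Ehrlich cells (Mus musculus) for antiproliferative activity, read by trypan blue exclusion, with a stated time of 2 h (a higher number here means a weaker inhibitor, a lower number a stronger inhibitor), compound 1 `N#CC1=C(N)N(c2ccc(S(N)(=O)=O)cc2)C2=C(C(=O)CCC2)C1c1ccc(O)cc1` gives 3 ug/mL. Compound 2 `N#CC1=C(N)N(c2ccc(S(N)(=O)=O)cc2)C2=C(C(=O)CCC2)C1c1c(O)ccc2ccccc12` carries a 2-hydroxynaphthalen-1-yl group where compound 1 carries 4-hydroxyphenyl. In this assay compound 2 shows only a limit, > 100 ug/mL. Compound 3 `N#CC1=C(N)N(c2ccc(S(N)(=O)=O)cc2)C2=C(C(=O)CCC2)C1c1ccco1` carries a furan-2-yl group in the same place. Compound 3 likewise shows only a limit, > 100 ug/mL. Both replacements read as large moves toward weaker inhibition: an at least 33-fold higher number from compound 1 to compound 2 (1.52 log units; beyond the scatter) and an at least 33-fold higher number from compound 1 to compound 3 (1.52 log units; beyond the scatter). The step between the two weaker compounds cannot be read, a step that the two limits leave unreadable from compound 2 to compound 3, since (the limit of > 100 ug/mL in this assay, at which 2 of the 3 values shown sit). Compound 3 thus stands at the limit of this assay, with no number of its own.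

Compound 4 `Cc1ccoc1C1C(C#N)=C(N)N(c2ccc(S(N)(=O)=O)cc2)C2=C1C(=O)CCC2` differs from compound 3 in a single point: methyl in place of hydrogen on an aromatic carbon. Going by the values given here, no measured step involves a methyl group on this ring, so nothing measured here says how far a change of this kind moves the number. Among the compounds with values here, the measured steps show only that the group on that saturated carbon matters greatly and that the furan of compound 3 sits at the limit. The expected step is a number no higher from compound 3 to compound 4 (the limit leaves the size open). Compound 4 is estimated at 100 ug/mL, between 30 ug/mL and 300 ug/mL, and is most likely reported again only as a limit.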

Compound 4, half-maximal inhibitory concentration: > 100 ug/mL
Compound 4 gave a limit, no number; the forecaster's own chance of this, stated with the estimate: 70%; the middle value sits exactly at the limit.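

Placing a methyl on this furan, on the ring carbon next to the ring atom that bears the large group, does not bring a readable number into view: in this assay compound 4 gives > 100 ug/mL, which is a limit and not a number. The 3-methylfuran-2-yl group thus joins furan-2-yl and 2-hydroxynaphthalen-1-yl on the weak side of the 4-hydroxyphenyl group, with an at least 33-fold higher number from compound 1 to compound 4 (1.52 log units; beyond the scatter). The steps among the three weaker compounds cannot be read, because each of them rests on a limit at both ends: the limit of > 100 ug/mL in this assay, at which 3 of the 4 values shown sit.

The compounds shown leave open whether the methyl moves the activity at all, since neither compound 3 nor compound 4 has a number of its own. They also leave open whether an amine, a carboxylic acid or a longer chain on this furan carbon would give a value that can be read against compound 1.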